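Aryl swap on the amino nitrogen: compound 1 to compound 4

The source may report more compounds than this note shows. Statements on the series, on what has been measured and on what is new or still open speak of the compounds shown alone.

In a functional assay on OVCAR-3 cells (Homo sapiens) for antiproliferative activity, read by spectrophotometry, with a stated time of 2 days (a lower number here means a stronger inhibitor of growth, a higher number a weaker inhibitor of growth), compound 1 `Cc1ccc(Nc2ncc(C(F)(F)F)c(N3Cc4cccc(N(C)S(C)(=O)=O)c4C3)n2)c(Cl)c1` reads > 30000 nM, which is a limit of the assay and not a number. Compound 3 `CN(c1cccc2c1CN(c1nc(Nc3cc(C(F)(F)F)cc(C(F)(F)F)c3)ncc1C(F)(F)F)C2)S(C)(=O)=O` reads > 30000 nM, again a limit and not a number. Compound 2 `CN(c1cccc2c1CN(c1nc(Nc3cccc(Oc4ccccc4)c3)ncc1C(F)(F)F)C2)S(C)(=O)=O` is the only one of the measured set with a number, at 24900 nM. Taken together, the series so far shows (the limit of > 30000 nM in this assay, at which 2 of the 3 values shown sit).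

Compound 4 `Cc1cc(C)cc(Nc2ncc(C(F)(F)F)c(N3Cc4cccc(N(C)S(C)(=O)=O)c4C3)n2)c1` carries 3,5-dimethylphenyl in place of 2-chloro-4-methylphenyl on a nitrogen on an aromatic ring. The core of compound 1 stays unchanged. For the measured compounds named here, no two measured compounds differ in one place only, and no measured step speaks directly to this change.

The expectation therefore rests on the three measured compounds, none of which shows strong growth inhibition in this assay. No step beyond the usual scatter is expected in either direction, and a limit reading is about as likely as a number. The estimated change is an at least 1.2-fold lower number from compound 1 to compound 4 (0.07 log units; that floor lies within the scatter), and it is expected to stay within that scatter. Compound 4 is estimated at 25000 nM, with an expected range from 10000 nM to 45000 nM.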

Compound 4, concentration for 50% growth inhibition: > 30000 nM
Compound 4 gave a limit, no number (the forecaster's own chance of this, stated with the estimate: 55%); at least 1.2-fold (0.07 log units) between middle value and limit.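

In this assay compound 4 gives > 30000 nM, a limit of the assay and not a number. For the compounds shown here, compound 1 gives > 30000 nM, also a limit, so no step between compound 1 and compound 4 can be read. The compounds shown leave open whether 3,5-dimethylphenyl and 2-chloro-4-methylphenyl differ at all in this read-out, with most values resting at one limit: the limit of > 30000 nM in this assay, at which 3 of the 4 values shown sit.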